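The compounds below may be only part of what the source reports. "The series", "measured", "known", "first", "only" and "open" are said of these compounds alone.

Measured so far: compound 1 `COc1ccc(C(=O)N(Cc2ccncc2)Cc2cccc(OCC3CCCCC3)c2)cc1` with 19700 nM in a functional assay on KMS-11 cells (Homo sapiens) for antiproliferative activity, read by CellTiter-Glo, with a stated time of 72 h; on this read-out higher numbers stand for weaker inhibition and lower numbers for stronger inhibition; compound 2 `COc1ccc(C(=O)N(Cc2ccncc2)Cc2cccc(OCc3ccc([N+](=O)[O-])cc3)c2)cc1` with 15400 nM.

Within the data shown here, only two compounds carry numbers. Among the measured compounds shown here, compound 2 and compound 1 sit close together: the single step that joins them is a 1.3-fold lower number from compound 1 to compound 2 (0.11 log units; within the scatter), so the two values cannot be told apart with confidence, and neither compound can be called the more active of the pair.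

Compound 3 `COc1ccc(C(=O)N(Cc2ccncc2)Cc2cccc(OCc3cccc(OC)c3)c2)cc1` has not yet been measured in this assay. It differs from compound 2 in one place: 3-methoxyphenyl in place of 4-nitrophenyl on a saturated chain carbon bound to an oxygen on an aromatic ring. For the measured compounds named here, the only measured step that touches the same position, from compound 1 to compound 2, exchanged cyclohexyl for 4-nitrophenyl on the saturated chain carbon bound to an oxygen on an aromatic ring, and that exchange moved the number by a 1.3-fold lower number from compound 1 to compound 2 (0.11 log units; within the scatter). Going by the values given here, nothing beyond that one step is known about this position, and no step involves a 3-methoxyphenyl group at all.

On that basis compound 3 is expected to stay close to compound 2, with a step of a 1.0-fold higher number from compound 2 to compound 3 (0.02 log units; within the scatter) that does not leave the scatter. Compound 3 is therefore estimated at 16000 nM, with a range from 6000 nM to 45000 nM.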

Compound 3, half-maximal inhibitory concentration: 16900 nM
Compound 3: the middle estimate sits 1.1-fold (0.02 log units) below what was measured, and the stated range covers the measured number.
By their numbers in this assay, from the lowest: compounds 2, 3 and 1 (each within the scatter of the next).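

In this assay, putting 3-methoxyphenyl in place of 4-nitrophenyl on the saturated chain carbon bound to an oxygen on an aromatic ring gives a 1.1-fold higher number from compound 2 to compound 3 (0.04 log units; within the scatter), and putting it in place of cyclohexyl gives a 1.2-fold lower number from compound 1 to compound 3 (0.07 log units; within the scatter). Among these compounds, the earlier pair offered only one exchange at this place, whereas three groups can now be compared, and all three steps among them stay within the scatter, so cyclohexyl, 4-nitrophenyl and 3-methoxyphenyl cannot be told apart here, even though the two aromatic groups differ in their atoms and in their hydrogen-bond acceptor counts. No supporting information is available to account for this result.

The compounds shown leave open whether any group at this place would separate from these three, for example a primary amine, a carboxylic acid or a longer alkyl chain on the same oxygen. They also leave open whether a change elsewhere on the shared core would move the number beyond the scatter, since every comparison so far concerns this one place.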